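The source may hold more compounds than are shown below. What is called first, only, known or untested is meant among the compounds shown, and "the series" means these compounds.

Compound 1 `COc1ccc(-n2nnnc2Nc2ccc(F)cc2)cc1` gives 155000 nM
Compound 2 `COc1ccc(-n2nnnc2Nc2cccc(F)c2)cc1` gives 127000 nM

Both numbers come from an ADME assay on HaCaT cells (Homo sapiens) for cytotoxicity, read by MTT assay, with a stated time of 72 h; on this read-out lower numbers stand for stronger inhibition and higher numbers for weaker inhibition. Compound 2 stands at 127000 nM and compound 1 at 155000 nM, so the two lie within the usual scatter of each other and neither can be ranked above the other.

The next compound, compound 3 `COc1ccc(-n2nnnc2Nc2ccccc2F)cc1`, has not yet been measured. It has the same atoms as compound 2, joined differently, with 2-fluorophenyl in place of 3-fluorophenyl on a nitrogen on an aromatic ring.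

Among the measured compounds shown here, only one measured step bears on this change, a similar swap at the same place. That step is a 1.2-fold lower number from compound 1 to compound 2 (0.09 log units; within the scatter), with 3-fluorophenyl in place of 4-fluorophenyl, and it stays within the scatter. For the measured compounds named here, no compound carrying 2-fluorophenyl has been measured, so this single step is thin evidence. Even so, no shift beyond the scatter is expected in this assay, in either direction. The expected step is a 1.1-fold higher number from compound 2 to compound 3 (0.03 log units; within the scatter) and it is only an estimate. For compound 3 the estimated value is 135000 nM, with an expected range from 75000 nM to 240000 nM.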

Compound 3, half-maximal inhibitory concentration: 111000 nM
Compound 3: the middle estimate sits 1.2-fold (0.09 log units) above what was measured, within the range that was stated.
By their numbers in this assay, from the lowest: compounds 3, 2 and 1 (each within the scatter of the next).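

The step of a 1.1-fold lower number from compound 2 to compound 3 (0.06 log units; within the scatter) and the step of a 1.4-fold lower number from compound 1 to compound 3 (0.15 log units; within the scatter) both come from this assay, and both stay within the usual scatter of repeated measurements. Until now only 4-fluorophenyl and 3-fluorophenyl could be compared on this nitrogen, but with 2-fluorophenyl added, all three fluorophenyl groups can be set side by side, and this read-out does not separate any of them, so no ranking among the three can be drawn from these numbers. Nothing measured here offers an explanation for how closely the three compounds agree.

From the compounds shown here alone, all three compounds carry a fluorophenyl group at this place on the shared core, so the effect of a different kind of group there, such as a chlorophenyl, a phenyl with an amine or a carboxylic acid on it, or a longer chain in place of the ring, remains open. These numbers also come from a single cell assay, so whether the three fluorophenyl groups would stay this close to one another in any other test is an open question as well.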